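A few compounds are considered here, and "the series" means these few. Any claim that something is new, unique, unknown or untested is made for them only; others in the source may bear on it.

Measured in a functional assay on HepG2 cells (Homo sapiens) for antiproliferative activity, read by XTT assay, with a stated time of 72 h; a lower number here means a stronger inhibitor, a higher number a weaker inhibitor:
- compound 1 `COc1ncnc2c1c(-c1ccccc1)cn2[C@@H]1O[C@H](CO)[C@@H](O)[C@H]1O`: > 20000 nM (a limit, not a number)
- compound 2 `COc1ncnc2c1c(-c1cc3ccccc3o1)cn2[C@@H]1O[C@H](CO)[C@@H](O)[C@H]1O`: > 20000 nM (a limit, not a number)
- compound 3 `CNc1ncnc2c1c(-c1ccoc1)cn2[C@@H]1O[C@H](CO)[C@@H](O)[C@H]1O`: > 20000 nM (a limit, not a number)

Compound 3 therefore has no number of its own, only a limit. The whole picture so far is the limit of > 20000 nM in this assay, at which 3 of the 3 values shown sit.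

Compound 4 `C#Cc1cn([C@@H]2O[C@H](CO)[C@@H](O)[C@H]2O)c2ncnc(NC)c12` differs from compound 3 in one place: ethynyl in place of furan-3-yl on an aromatic carbon. This puts ethynyl in place of furan-3-yl on an aromatic carbon. All three measured compounds carry a ring there, and ethynyl has no ring.

Going by the values given here, the only measured step at this place is a step that the two limits leave unreadable from compound 1 to compound 2. It swaps one ring-bearing group for another, its size cannot be read, and it says nothing about ethynyl. Among the compounds with values here, no measured step therefore sets a size or a firm direction in this assay. A further limit is the likeliest result, with some chance of a real number.

The estimated change is an at least 1.3-fold lower number from compound 3 to compound 4 (0.12 log units; that floor lies within the scatter).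

Compound 4 is expected to come in at about 15000 nM, with an estimated range from 3000 nM to 40000 nM.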

Compound 4, half-maximal inhibitory concentration: > 15000 nM
Compound 4: no number, only a limit; the forecaster's own chance of this, stated with the estimate: 60%; the middle value sits exactly at the limit.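

Compound 3 and compound 4 each have only a limit and not a number, so the step from furan-3-yl to ethynyl cannot be read. The compounds shown leave open how strongly any of them acts on these cells, and whether the group at this place changes that at all.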